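A few compounds are considered here, and "the series" means these few. Any claim that something is new, unique, unknown or untested is made for them only; others in the source may bear on it.

Measured compounds:
Compound 1 `O=C(Nc1cccc(CNc2nccnc2Cl)c1)Nc1cccc2ccccc12` gives > 40000 nM in a functional assay on HepG2 cells (Homo sapiens) for antiproliferative activity, read by MTT assay, with a stated time of 48 h (a higher number here means a weaker inhibitor, a lower number a stronger inhibitor), which is a limit of the assay rather than a number.
Compound 2 `CCc1ccc(NC(=O)Nc2cccc(CNc3nccnc3Cl)c2)c(CC)c1` gives 10800 nM in this assay.

Among the measured compounds shown here, compound 2 holds the only numeric value shown in this assay; the other value shown sits at the limit of > 40000 nM in this assay, at which 1 of the 2 values shown sits. Compound 3 `CCc1ccccc1NC(=O)Nc1cccc(CNc2nccnc2Cl)c1` differs from compound 2 by hydrogen in place of ethyl on an aromatic carbon. For the measured compounds named here, no step between measured compounds is available, so the size of this change in this assay can only be expected: a modest weakening, around the edge of the scatter, is expected, a 1.9-fold higher number from compound 2 to compound 3 (0.27 log units; within the scatter). Compound 3 is therefore estimated at 20000 nM, with a range from 8000 nM to 50000 nM.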

Compound 3, half-maximal inhibitory concentration: 7860 nM
For compound 3 the middle estimate is 2.5-fold (0.41 log units) above the measured one, and the stated range ends above it.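

Replacing ethyl with hydrogen on this aromatic carbon, para to a large group, gives a 1.4-fold lower number from compound 2 to compound 3 (0.14 log units; within the scatter) in this assay. Among the compounds shown here, this is the first step that can be read at this position, and it shows that compound 2 and compound 3 cannot be told apart here, so the ethyl at this place makes no measurable difference to the read-out. The value of compound 1 is a limit and not a number, so no step to it can be read: the limit of > 40000 nM in this assay, at which 1 of the 3 values shown sits.

The compounds shown leave open whether the remaining ethyl group matters. They also leave open how an amine or a carboxylic acid would fare at the position now carrying hydrogen.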